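Adding a bromo group to compound 2

The source may hold more compounds than are shown below. What is called first, only, known or untested is meant among the compounds shown, and "the series" means these compounds.

Compound 1 `N#Cc1c(Br)n(COCc2ccccc2)c2ncnc(N)c12` gives > 100000 nM
Compound 2 `CCOCn1cc(C#N)c2c(N)ncnc21` gives > 100000 nM

Both readings come from a functional assay on KB cells (Homo sapiens) for inhibition (a lower number here means a stronger inhibitor, a higher number a weaker inhibitor), and neither is a true number. Compound 2 stands at > 100000 nM, which is a limit of the assay. Compound 1 reads > 100000 nM, which is also a limit. Together they give this picture: the limit of > 100000 nM in this assay, at which 2 of the 2 values shown sit.

The next compound, compound 3 `CCOCn1c(Br)c(C#N)c2c(N)ncnc21`, is compound 2 with bromo in place of hydrogen on an aromatic carbon.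

For the measured compounds named here, no measured step is available to size this change, so the expectation starts from the limit of compound 2 at > 100000 nM. In this assay, no change beyond the scatter is expected, and another limit reading is the likeliest outcome. The estimated step is a number no higher from compound 2 to compound 3 (the limit leaves the size open). Compound 3 is expected at about 100000 nM, with an estimated range of 20000 nM to 200000 nM.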

Compound 3, half-maximal inhibitory concentration: > 100000 nM
Compound 3: a limit, no number (the forecaster's own chance of this, stated with the estimate: 70%); the middle value sits exactly at the limit.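

The steps from compound 2 to compound 3 and from compound 1 to compound 3 cannot be read, because all three compounds sit at a limit: the limit of > 100000 nM in this assay, at which 3 of the 3 values shown sit.

The compounds shown leave open whether bromo in place of hydrogen on an aromatic carbon changes inhibition in this assay at all.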